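A second chloro on the chlorophenyl group

The source may hold more compounds than are shown below. What is called first, only, known or untested is meant among the compounds shown, and "the series" means these compounds.

In a physicochemical assay for solubility, at pH 7.4 (on this read-out lower numbers stand for lower solubility and higher numbers for higher solubility), compound 1 `O=C(N[C@H]1CN(S(=O)(=O)c2ccccc2)C[C@@H]1C(=O)N[C@H]1CCCNC1)c1cn(C2CC2)cn1` gives 664000 nM and compound 2 `O=C(N[C@H]1CN(S(=O)(=O)c2ccccc2)C[C@@H]1C(=O)N[C@H]1CCCNC1)c1cc(-c2ccc(Cl)cc2)on1` gives 12000 nM as the lower of the two numbers. Compound 3 `O=C(N[C@H]1CN(S(=O)(=O)c2ccccc2)C[C@@H]1C(=O)N[C@H]1CCCNC1)c1cc(-c2ccc(Cl)cc2Cl)on1` is compound 2 with one small edit. That edit chloro in place of hydrogen on an aromatic carbon is chloro in place of hydrogen on an aromatic carbon, so 4-chlorophenyl becomes 2,4-dichlorophenyl. Among the compounds with values here, only one measured step bears on this, namely a 55-fold lower number from compound 1 to compound 2 (1.74 log units; beyond the scatter) on putting 5-(4-chlorophenyl)-1,2-oxazol-3-yl in place of 1-cyclopropyl-1H-imidazol-4-yl. That was a large step from replacing a whole group, whereas here one atom is added, so it is a loose guide. With a 55-fold lower number from compound 1 to compound 2 (1.74 log units; beyond the scatter) as the only reference, a much smaller step in the same downward direction is expected in this assay and may barely clear the scatter. The expected change is a 2.0-fold lower number from compound 2 to compound 3 (0.30 log units; within the scatter) on this estimate. Compound 3 is estimated at 6000 nM within a range of 2000 nM to 15000 nM for now.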

Compound 3, solubility: 4000 nM
Compound 3: middle estimate off by 1.5-fold (0.18 log units), on the high side; measured number inside the range.
By their numbers in this assay, from the lowest: compound 3; then compound 2; then compound 1.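

In this assay, the step of a 3.0-fold lower number from compound 2 to compound 3 (0.48 log units; beyond the scatter) comes from adding one chloro, ortho to a large group and meta to the chloro already on the aromatic ring. This shows that a single added heavy atom at this position can move the number beyond the usual scatter, though the step is only modest. The earlier step replaced a whole group and could not show what one atom on this ring does, and no measurement here explains the new step.

From the compounds shown here alone, whether this step is specific to chloro remains open, since a fluoro group, a methoxy group or an amine at the same position could move the number differently. The compounds shown also leave open how a lone chloro at this position would behave without the existing chloro.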